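Losing a ring-carbon hydroxy: compound 2 to compound 3

A few compounds are considered here, and "the series" means these few. Any claim that something is new, unique, unknown or untested is made for them only; others in the source may bear on it.

- compound 1 `Oc1cc(O)cc(CCCCCCCCCCCCCCc2cc(O)cc(O)c2)c1`: 29800 nM
- compound 2 `Oc1cc2cc(c1)Oc1c(O)cc(cc1O)[C@H](O)CCCCCC/C=C/CCCCC2`: 31300 nM

In a functional assay on SF-268 cells (Homo sapiens) for cytotoxicity (a higher number here means a weaker inhibitor, a lower number a stronger inhibitor), compound 2 stands at 31300 nM, within the scatter of compound 1 at 29800 nM. Compound 3 `Oc1cc2cc(c1)Oc1c(O)cc(cc1O)CCCCCCC/C=C/CCCCC2` has not yet been measured. It differs from compound 2 by hydrogen in place of hydroxy on a saturated ring carbon, with hydrogen in place of hydroxy on a saturated ring carbon. For the measured compounds named here, no measured pair shows what such a change does in this assay, so no step beyond the scatter is expected, in either direction. The estimated change is a 1.1-fold lower number from compound 2 to compound 3 (0.05 log units; within the scatter). For compound 3 the expected value is 28000 nM, with an estimated range of 11000 nM to 65000 nM.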

Compound 3, half-maximal inhibitory concentration: 33100 nM
Compound 3: middle estimate off by 1.2-fold (0.07 log units), on the low side, within the range that was stated.
By their numbers in this assay, from the lowest: compounds 1, 2 and 3 (each within the scatter of the next).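

In this assay, for the compounds shown here, the first measured pair at this saturated ring carbon gives a 1.1-fold higher number from compound 2 to compound 3 (0.02 log units; within the scatter) and so shows that hydrogen can stand in place of the hydroxy there without a step beyond the scatter. On this evidence, the hydroxy on this carbon is not needed to keep the number where it is. No measured evidence bears on this result.

Still open, on these data alone, is whether an amine or a carboxylic acid on this same ring carbon would leave the number unmoved. The compounds shown also do not say whether a methoxy there would behave as hydrogen does.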